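This account rests on a few compounds, and the source may have more. Where it says the series, first, only, none or still open, it means among the compounds named here.

In a functional assay on the whole organism for antagonist activity, with Mus musculus as the target (on this read-out higher numbers stand for an effect only at larger amounts of compound and lower numbers for an effect already at smaller amounts), compound 1, `CCC(=O)N(c1cccc(C)c1)C1CCCC1N(C)C`, gives 1 mg/kg; 1 mg/kg (2 entries), the two entries agreeing with one another. For the measured compounds named here, compound 2, `CCC(=O)N(c1cccc(OC)c1)C1CCCC1N(C)C`, stands apart from it on this read-out: in this assay compound 2 gives 4 mg/kg, which is the only number recorded for it, a further determination having returned no single number. The difference between compound 1 and compound 2 is a methyl exchanged for a methoxy on the aromatic ring, and the gap between the two values lies beyond the usual scatter, with compound 2 needing the larger dose.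

Compound 3, `CCC(=O)N(c1cccc(F)c1)C1CCCC1N(C)C`, has not yet been tested in this assay. It differs from compound 2 in one place: fluoro in place of methoxy on an aromatic carbon. The fluoro substituent is closer in size to the methyl of compound 1 than to the methoxy of compound 2, so a step toward smaller doses is expected, of a size that may not exceed the scatter: a 2.0-fold lower number from compound 2 to compound 3 (0.30 log units; within the scatter). For compound 3 in this assay the estimate is 2 mg/kg, between 1 mg/kg and 5 mg/kg.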

Compound 3, dose for half-maximal effect: 0.6 mg/kg
For compound 3 the middle estimate is 3.3-fold (0.52 log units) above the measured one; the whole stated range lies above it.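

Fluoro in place of methoxy on this aromatic carbon gives a 6.7-fold lower number from compound 2 to compound 3 (0.82 log units; beyond the scatter) in this assay and so moves the read-out clearly, a change on this ring carbon that now shows in a second exchange after the earlier contrast of methyl and methoxy. Compound 3 gives 0.6 mg/kg and compound 1 gives 1 mg/kg; 1 mg/kg (2 entries) in the same read-out, two values within the usual scatter of each other, so methyl and fluoro cannot be told apart here, while methoxy in compound 2 stands apart from both. Nothing measured on these compounds bears on why the methoxy compound needs the larger dose.

From the compounds shown here alone, how a chloro, a nitrile or an amine would read on this carbon stays open. So does whether the step from methoxy to fluoro keeps its size with a longer chain on the carbonyl.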